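A few compounds are considered here, and "the series" means these few. Any claim that something is new, unique, unknown or untested is made for them only; others in the source may bear on it.

Compound 3 `Cc1cc(C(=O)Nc2c(F)cccc2F)nn1Cc1cc(Cl)ccc1OCc1ccccc1` gives 3.7 in a physicochemical assay for lipophilicity, at pH 7.4; on this read-out lower numbers stand for lower lipophilicity and higher numbers for higher lipophilicity. Of the two numbers shown it stands highest; the other number belongs to compound 2 `Cc1cc(C(=O)Nc2ccc(F)cc2)nn1Cc1cc(Cl)ccc1OCc1ccccc1`, which in this assay gives 3. The step between them was a number 0.70 log units higher from compound 2 to compound 3 (beyond the scatter). Compound 1 `Cc1cc(C(=O)NC(C)C)nn1Cc1cc(Cl)ccc1OCc1ccccc1` is reported in this assay only as a limit, > 3.7 (the limit of > 3.7 in this assay, at which 1 of the 3 values shown sits). Compound 4 `Cc1cc(C(=O)Nc2ccccn2)nn1Cc1cc(Cl)ccc1OCc1ccccc1` differs from compound 3 by pyridin-2-yl in place of 2,6-difluorophenyl on an amide-type nitrogen. Going by the values given here, three measured steps bear on changes at this same amide-type nitrogen: a number at least 0.70 log units lower from compound 1 to compound 2 (beyond the scatter), a number no higher from compound 1 to compound 3 (the limit leaves the size open) and a number 0.70 log units higher from compound 2 to compound 3 (beyond the scatter). None of them swaps a carbon-only ring for a ring with a hetero atom, so the size of the present step is open, yet the direction is expected to be downward, since pyridin-2-yl carries one hydrogen-bond acceptor where 2,6-difluorophenyl carries none. Compound 4 is therefore expected to give 2.7 in this assay, within 2.1 to 3.3. The expected step is a number 1.00 log units lower from compound 3 to compound 4 (beyond the scatter).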

Compound 4, distribution coefficient: > 3.7
Compound 4 gave a limit, no number; the forecaster's own chance of this, stated with the estimate: 5%; at least 1.00 log units between middle value and limit.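

In this assay compound 4 is reported only as a limit, > 3.7, and this places it with compound 1 at the same limit: the limit of > 3.7 in this assay, at which 2 of the 4 values shown sit. Pyridin-2-yl, the only ring shown with a hetero atom on this amide-type nitrogen, gave a number no lower from compound 3 to compound 4 (the limit leaves the size open), and it gave a number at least 0.70 log units higher from compound 2 to compound 4 (beyond the scatter). The hydrogen-bond acceptor counted on pyridin-2-yl therefore brought no drop in this read-out against either fluorinated phenyl ring, while the step between compound 1 and compound 4 cannot be read, as both values are limits.

Going by these compounds, how far compound 4 lies beyond compound 3 remains open. Also open, on these data alone, is whether a pyrimidinyl ring, or a pyridin-2-yl ring carrying a morpholine or a carboxylic acid, would give a number rather than a limit in this assay.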